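A few compounds are considered here, and "the series" means these few. Any claim that something is new, unique, unknown or untested is made for them only; others in the source may bear on it.

Three ureas built on one shared core were tested in a functional assay on SGC-7901 cells (Homo sapiens) for cytotoxicity, read by MTT assay, with a stated time of 72 h; a lower number here means a stronger inhibitor, a higher number a weaker inhibitor. Compound 1 `O=C(Nc1ccc(-n2ncc3c(Br)cccc32)cc1)Nc1ccc(Cl)c(C(F)(F)F)c1` gives 16600 nM. Compound 2 `O=C(Nc1ccc(-n2ncc3c(F)cccc32)cc1)Nc1ccc(Cl)c(C(F)(F)F)c1` gives 32000 nM. Compound 3 `Cc1cccc2c1cnn2-c1ccc(NC(=O)Nc2ccc(Cl)c(C(F)(F)F)c2)cc1` gives 14200 nM. Of these three numbers, compound 2 has the highest, but its gap to compound 1 lies within the scatter, and only its gap to compound 3 goes beyond it. The measured steps are all small: bromo to fluoro gives a 1.9-fold higher number from compound 1 to compound 2 (0.29 log units; within the scatter), bromo to methyl gives a 1.2-fold lower number from compound 1 to compound 3 (0.07 log units; within the scatter), and fluoro to methyl gives a 2.3-fold lower number from compound 2 to compound 3 (0.35 log units; beyond the scatter).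

Compound 4 `COc1cccc2c1cnn2-c1ccc(NC(=O)Nc2ccc(Cl)c(C(F)(F)F)c2)cc1` has not yet been measured. It differs from compound 2 in one place: methoxy in place of fluoro on an aromatic carbon. Nothing measured here shows a methoxy at that place, so the expectation leans on the step where fluoro gave way to methyl. A modest step toward a lower number in this assay is expected. Compound 4 is expected to give roughly 18000 nM, within a range from 7000 nM to 45000 nM, because a 2.3-fold lower number from compound 2 to compound 3 (0.35 log units; beyond the scatter) is the most comparable measured step. This amounts to an expected step of a 1.8-fold lower number from compound 2 to compound 4 (0.25 log units; within the scatter).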

Compound 4, half-maximal inhibitory concentration: 29800 nM
Estimate against measurement, compound 4: 1.7-fold (0.22 log units) below, and the stated range covers the measured number.
By their numbers in this assay, from the lowest: compounds 3, 1, 4 and 2 (each within the scatter of the next, the first and the last beyond it).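

In this assay, methoxy does not repeat what methyl did at this aromatic carbon: in place of fluoro it gives no readable change (a 1.1-fold lower number from compound 2 to compound 4 (0.03 log units; within the scatter)), and the same holds for methoxy in place of bromo (a 1.8-fold higher number from compound 1 to compound 4 (0.25 log units; within the scatter)). Methoxy in place of methyl is the one new step that goes beyond the scatter (a 2.1-fold higher number from compound 3 to compound 4 (0.32 log units; beyond the scatter)), so methyl and methoxy do not read alike at this place, although the step is modest. No measurement shown here explains that difference.

From the compounds shown here alone, whether any group at this carbon can move the number by more than a modest step remains open. An amine, a carboxylic acid or a longer chain such as ethoxy at the same place would test how far that limit holds.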